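A few compounds are considered here, and "the series" means these few. Any claim that something is new, unique, unknown or untested is made for them only; others in the source may bear on it.

Of the compounds shown here, three built on one shared core have been measured in an assay on CHO cells for displacement of a labelled ligand from Neuronal acetylcholine receptor; alpha3/beta4 (Homo sapiens), read by scintillation counting, with a stated time of 2 h; on this read-out higher numbers stand for weaker inhibition and lower numbers for stronger inhibition. Compound 1 `C[C@@H]1C[C@@H]1C(=O)N1CC2CNCC2C1` gives 280 nM, and compound 2 `C[C@@H]1C[C@H]1C(=O)N1CC2CNCC2C1` gives 360 nM; the only difference drawn between them is the fact that one of compounds 1 and 2 is drawn with a defined configuration and the other without, at the place where they differ, and the step of a 1.3-fold higher number from compound 1 to compound 2 (0.11 log units; within the scatter) is too small to count. Compound 3 `CCC(=O)N1CC2CNCC2C1`, which carries an ethyl group on the carbonyl carbon where the others carry a 2-methylcyclopropyl group, gives 2100 nM. The steps of a 7.5-fold higher number from compound 1 to compound 3 (0.88 log units; beyond the scatter) and a 5.8-fold higher number from compound 2 to compound 3 (0.77 log units; beyond the scatter) show that trading the small ring for the open chain weakens binding. Among the three numbers compound 2 therefore stands second highest, close to compound 1 and with a far lower number than compound 3.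

Compound 4 `COC(=O)N1CC2CNCC2C1` has not yet been measured. It arises from compound 2 by methoxy in place of 2-methylcyclopropyl on a carbonyl carbon. The measured steps that bear on this change are the two in which the same 2-methylcyclopropyl group gave way to a smaller group without a ring, a 5.8-fold higher number from compound 2 to compound 3 (0.77 log units; beyond the scatter) and a 7.5-fold higher number from compound 1 to compound 3 (0.88 log units; beyond the scatter); a weakening of roughly that size, pointing toward a higher number, is therefore expected here too. Compound 4 is estimated at 2000 nM, with a range from 700 nM to 6000 nM. This corresponds to an expected step of a 5.6-fold higher number from compound 2 to compound 4 (0.74 log units; beyond the scatter).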

Compound 4, inhibition constant: 14000 nM
Beside the measured number, compound 4's estimate is 7.0-fold (0.85 log units) below it, outside the stated range (above it).
By their numbers in this assay, from the lowest: compounds 1 and 2 (each within the scatter of the next); then compound 3; then compound 4.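

In this assay, the step of a 6.7-fold higher number from compound 3 to compound 4 (0.82 log units; beyond the scatter) shows that at this position the kind of group on the carbonyl carbon counts, and not only its size: ethyl and methoxy both have 2 heavy atoms and no ring, yet the number still rises. For the compounds shown here, the earlier compounds could not show this, as their only change beyond the scatter was the swap of 2-methylcyclopropyl for ethyl, whereas the swap for methoxy gives much larger steps, a 39-fold higher number from compound 2 to compound 4 (1.59 log units; beyond the scatter) and a 50-fold higher number from compound 1 to compound 4 (1.70 log units; beyond the scatter), both large. Removing the ring is therefore not the whole story in these compounds, since putting an oxygen where ethyl has a carbon, which brings in a hydrogen-bond acceptor, goes with a further weakening on top of the loss seen with ethyl.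

The compounds shown leave open whether plain cyclopropyl, without its methyl, would hold the numbers of compounds 1 and 2, and whether a longer chain such as propyl or an amine such as dimethylamino on the carbonyl carbon would land nearer compound 3 or compound 4. Nothing available here bears on why methoxy and ethyl differ.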